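Chlorobenzyl ether position in the melanin-concentrating hormone receptor series

The source may hold more compounds than are shown below. What is called first, only, known or untested is meant among the compounds shown, and "the series" means these compounds.

Of the compounds shown here, three have been measured in an assay on CHO cells for displacement of a labelled ligand from melanin-concentrating hormone receptor 1 (Homo sapiens), read by scintillation counting, with a stated time of 1 h; a higher number here means a weaker inhibitor, a lower number a stronger inhibitor. Compound 1 `Cn1c(C2CC2)nc2ccc(-n3ccc(OCc4ccc(Cl)cc4)cc3=O)cc21` gives 35 nM, compound 2 `Cn1c(C2CC2)nc2ccc(-n3ccc(OCc4ccc(F)cc4)cc3=O)cc21` gives 40 nM, and compound 3 `Cn1c(C2CC2)nc2ccc(-n3ccc(OCc4cccc(Cl)c4)cc3=O)cc21` gives 100 nM, the highest of the three numbers; its nearest neighbour is compound 2 and its furthest is compound 1.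

Going by the values given here, the steps that bear on compound 3 are a 2.9-fold higher number from compound 1 to compound 3 (0.46 log units; beyond the scatter) and a 2.5-fold higher number from compound 2 to compound 3 (0.40 log units; beyond the scatter); both are modest and point the same way, so moving the halogen around the benzyl ring has so far cost potency. The exchange of halogen at the same position, a 1.1-fold higher number from compound 1 to compound 2 (0.06 log units; within the scatter), made no difference beyond the scatter.

Compound 4 `Cn1c(C2CC2)nc2ccc(-n3ccc(OCc4ccccc4Cl)cc3=O)cc21` differs from compound 3 in one place: 2-chlorophenyl in place of 3-chlorophenyl on a saturated chain carbon bound to an oxygen on an aromatic ring. Among the compounds with values here, no measured step covers the 2-chlorophenyl variant, so the expectation rests only on the observation that the single change of chloro position already measured cost a modest step. The most plausible estimate for compound 4 is therefore a number close to that of compound 3, with the step of a 1.2-fold higher number from compound 3 to compound 4 (0.08 log units; within the scatter) expected to remain within the scatter, though a further loss cannot be ruled out. In this assay compound 4 is estimated at 120 nM, with a likely range from 40 nM to 350 nM.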

Compound 4, half-maximal inhibitory concentration: 160 nM
Compound 4: the middle estimate sits 1.3-fold (0.12 log units) below what was measured; low and high end bracket the measured number.
By their numbers in this assay, from the lowest: compounds 1 and 2 (each within the scatter of the next); then compounds 3 and 4 (each within the scatter of the next).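

In this assay the 2-chlorophenyl and 3-chlorophenyl ethers are not separated (a 1.6-fold higher number from compound 3 to compound 4 (0.20 log units; within the scatter)), so the chloro position has now been read at all three named places on the benzyl ring and only two levels appear. The 2-chlorophenyl ether also lies clearly apart from the two 4-substituted ethers, with modest steps (a 4.6-fold higher number from compound 1 to compound 4 (0.66 log units; beyond the scatter)) and (a 4.0-fold higher number from compound 2 to compound 4 (0.60 log units; beyond the scatter)), so the earlier loss seen with compound 3 is not peculiar to 3-chlorophenyl; within these four compounds, the two with a 4-halogen give the lower numbers and none goes against this. Nothing available explains why the 4-substituted ethers differ from the other two.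

Still open, on these data alone, is whether this dependence on position holds for fluoro, as 2-fluorophenyl and 3-fluorophenyl would show, since the fluoro case rests on 4-fluorophenyl alone. The compounds shown also leave open whether phenyl without a halogen, 4-methoxyphenyl, 4-cyanophenyl or a longer chain such as phenethyl in place of benzyl would stay level with compound 1 or fall with compound 3 and compound 4.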